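Trading 4-aminophenyl for a 3-(dimethylamino)propyl chain

The source may hold more compounds than are shown below. What is called first, only, known or untested is meant among the compounds shown, and "the series" means these compounds.

In a functional assay on HCT-116 cells (Homo sapiens) for cytotoxicity, read by MTT assay, with a stated time of 72 h (on this read-out higher numbers stand for weaker inhibition and lower numbers for stronger inhibition), compound 3 (`Nc1ccc(Nc2c(C(=O)NCc3ccc(F)cc3)nc(Br)c3cccnc23)cc1`) gives 7000 nM, the lower of the two actual numbers. The other number comes from compound 2 (`NCCCNc1c(C(=O)NCc2ccc(F)cc2)nc(Br)c2cccnc12`), which gives 18000 nM. Compound 1 (`Nc1cccc(Nc2c(C(=O)NCc3ccc(F)cc3)nc(Br)c3cccnc23)c1`) reads > 10000 nM, which is a limit and not a number.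

Compound 4 (`CN(C)CCCNc1c(C(=O)NCc2ccc(F)cc2)nc(Br)c2cccnc12`) differs from compound 3 as follows: 3-(dimethylamino)propyl in place of 4-aminophenyl on a nitrogen on an aromatic ring. The measured step that bears on this is a 2.6-fold lower number from compound 2 to compound 3 (0.41 log units; beyond the scatter), where 4-aminophenyl took the place of 3-aminopropyl. With a propyl chain returning, the expected change is a 2.1-fold higher number from compound 3 to compound 4 (0.33 log units; beyond the scatter), a higher number of similar size. Compound 4 is estimated at 15000 nM, with an expected range of 6000 nM to 35000 nM.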

Compound 4, half-maximal inhibitory concentration: > 10000 nM
Compound 4 was reported as a limit (the forecaster's own chance of this, stated with the estimate: 30%); the middle value does not contradict the limit.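

Compound 4 reads > 10000 nM in this assay, which is a limit and not a number. Replacing 4-aminophenyl with 3-(dimethylamino)propyl on this nitrogen gives an at least 1.4-fold higher number from compound 3 to compound 4 (0.15 log units; that floor lies within the scatter), so this floor alone does not establish a real loss at this position. The other two new steps cannot be read: the limit of > 10000 nM in this assay, at which 2 of the 4 values shown sit.

Going by these compounds, the true reading of compound 4 remains open, and with it whether dimethylamino differs from amino at the end of the chain. Also open, on these data alone, is how a longer chain or a piperidine on this nitrogen would read.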